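The source may hold more compounds than are shown below. What is called first, only, known or untested is meant among the compounds shown, and "the series" means these compounds.

Compound 2 `O=C(O)CC1(CCc2ccc(OCc3ccc4ccccc4n3)cc2)CCCC1` and compound 1 `CC(CCc1ccc(OCc2ccc3ccccc3n2)cc1)Cc1nnn[nH]1` share one core and differ in the end of their chain. In an assay on membranes from lung (Cavia porcellus) for binding affinity to cysteinyl leukotriene receptor (Homo sapiens) (a lower number here means a stronger inhibitor, a higher number a weaker inhibitor), compound 1 gives 25 nM, while compound 2 gives 51 nM. Of the two numbers in this assay, compound 2 thus stands at the higher one; the step of a 2.0-fold higher number from compound 1 to compound 2 (0.31 log units; beyond the scatter) exchanges both the end group and the branching carbon at once. Within the data shown here, no measured pair separates these two changes from each other.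

Compound 3 `c1ccc2nc(COc3ccc(CCC4(Cc5nnn[nH]5)CCCC4)cc3)ccc2c1` keeps the ring of compound 2 and changes only the end group: 1H-tetrazol-5-yl in place of carboxy on a saturated chain carbon bound to a saturated ring carbon. Among the measured compounds shown here, only the step from compound 1 to compound 2 bears on this exchange, and it ran towards a higher number when the tetrazole was replaced by the carboxy group, together with the ring. Returning to the tetrazole while keeping the ring is therefore expected to give, at most, a modest step back towards a lower number in this assay, a 1.8-fold lower number from compound 2 to compound 3 (0.26 log units; within the scatter), or none beyond the scatter. For compound 3 the estimate in this assay is 28 nM, with a range from 10 nM to 70 nM.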

Compound 3, inhibition constant: 25 nM
The estimate for compound 3 lay 1.1-fold (0.05 log units) above the measured number, within the range that was stated.
By their numbers in this assay, from the lowest: compounds 1 and 3 (each within the scatter of the next); then compound 2.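

With the ring of compound 2 held in place, the exchange of carboxy for 1H-tetrazol-5-yl on a saturated chain carbon bound to a saturated ring carbon now stands alone, and it gives a 2.0-fold lower number from compound 2 to compound 3 (0.31 log units; beyond the scatter) in this assay, a modest step but one that can be read for the end group by itself. The earlier step changed the end group and the branching carbon together; now, with the tetrazole present in both, compound 1 gives 25 nM and compound 3 gives 25 nM, so the printed values show no difference between the branching carbon of compound 1 and the ring of compound 3. No measurement shown here explains why the tetrazole and the carboxy group differ in this way.

The compounds shown leave open whether the same exchange would give a step of this size on the branched chain of compound 1, which would need a carboxylic acid there to complete the comparison. They also leave open how the number would respond to a longer chain between the saturated ring carbon and the tetrazole, or to an acylsulfonamide as the end group.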